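The compounds below may be only part of what the source reports. "The series", "measured", "known", "first", "only" and "open" are said of these compounds alone.

Working notes on the ester and ketone series.

Two compounds have numbers in a physicochemical assay for lipophilicity; a lower number here means a more polar compound, a higher number a more lipophilic compound. Compound 1, `CCCOC(=O)/C=C(C)/C=C/CC(C)CCCC(C)C`, gives 7.28 in this assay. Compound 2, `C=CC(C)OC(=O)/C=C(C)/C=C/CC(C)CCCC(C)(C)OC`, gives 5.94 in this assay, the lower of the two numbers, and the gap to compound 1 lies beyond the usual scatter. The two differ in more than one place, so their pair says only what the two values show.

Compound 3, `CCC(=O)/C=C(C)/C=C/CC(C)CCCC(C)(C)OC`, has no number yet. It follows from compound 2 by one change: ethyl in place of (1-methylprop-2-en-1-yl)oxy on a carbonyl carbon. What leaves carries one hydrogen-bond acceptor and five heavy atoms; what enters carries none and two heavy atoms, and the carbonyl carbon now joins two chain carbons.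

Going by the values given here, no measured pair in this set isolates this change, so the expectation rests on the size of the swap alone. A step downward in this assay, beyond the scatter, is expected from compound 2 to compound 3, of about a number 1.34 log units lower from compound 2 to compound 3 (beyond the scatter). For compound 3 the estimated value in this assay is 4.6, expected to fall between 3.9 and 5.3.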

Compound 3, partition coefficient: 5.07
Compound 3: middle estimate off by 0.47 log units, on the low side; measured number inside the range.
By their numbers in this assay, from the lowest: compound 3; then compound 2; then compound 1.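

The series now has its first comparison confined to one place: with ethyl in place of (1-methylprop-2-en-1-yl)oxy on a carbonyl carbon, this assay gives a number 0.87 log units lower from compound 2 to compound 3 (beyond the scatter). The gap between compound 1 and compound 2 could not be assigned to any single place, whereas this step belongs to one exchange, ((1-methylprop-2-en-1-yl)oxy)carbonyl to propanoyl, and shows that the read-out responds to a change at this position. Nothing available bears on why the number moves as it does.

The exchange alters several counted features together, removing a hydrogen-bond acceptor, reducing the heavy atoms and losing a double bond outside aromatic rings, so this single step cannot separate their contributions. Still open, from the compounds shown here alone, are the values that a methyl group, a longer chain such as butyl, or an amine on the same carbonyl carbon would give, and whether the same exchange on the core of compound 1 would give a step of similar size.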